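Replacing 2-phenylethenyl with butyl on compound 3

This account rests on a few compounds, and the source may have more. Where it says the series, first, only, none or still open, it means among the compounds named here.

Measured so far in an ADME assay on HepG2 2.2.15 cells (Homo sapiens) for cytotoxicity, read by MTT assay; a lower number here means that less compound is tolerated, a higher number that more compound is tolerated:
- Compound 1 `C=C1CC[C@@H]2[C@](C)(COC(=O)c3cccnc3)[C@H](O)CC[C@@]2(C)[C@@H]1/C=C/C1=CCOC1=O`: 113000 nM
- Compound 2 `C=C1CC[C@@H]2[C@](C)(COC(=O)c3ccco3)[C@H](O)CC[C@@]2(C)[C@@H]1C/C=C1\C=COC1=O`: > 2150000 nM
- Compound 3 `C=C1CC[C@@H]2[C@](C)(CO)[C@H](OC(=O)/C=C/c3ccccc3)CC[C@@]2(C)[C@@H]1C/C=C1\C=COC1=O`: 179000 nM

The entry for compound 2 is a limit of the assay and not a number. Compound 3, at 179000 nM, lies within the scatter of compound 1, at 113000 nM. Within the data shown here, these two are therefore the only numbers available in this assay, and they do not separate.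

The account now turns to compound 4 `C=C1CC[C@@H]2[C@](C)(CO)[C@H](OC(=O)CCCC)CC[C@@]2(C)[C@@H]1C/C=C1\C=COC1=O`, which has not yet been measured. It differs from compound 3 in one place: butyl in place of 2-phenylethenyl on a carbonyl carbon.

Among the measured compounds shown here, no measured pair of compounds differs in only one place, so the data offer no direct precedent for this change. The expectation therefore starts from compound 3 at 179000 nM, and no step beyond the scatter is expected. The estimated change is a 1.2-fold higher number from compound 3 to compound 4 (0.09 log units; within the scatter), a small expected rise that stays within the scatter. For compound 4 the expected value is 220000 nM, with an estimated range from 80000 nM to 700000 nM.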

Compound 4, half-maximal cytotoxic concentration: 126000 nM
Compound 4: middle estimate off by 1.7-fold (0.24 log units), on the high side; the range from low to high includes it.
By their numbers in this assay, from the lowest: compounds 1, 4 and 3 (each within the scatter of the next). At a limit, above all of these: compound 2.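

Among these compounds, the step of a 1.4-fold lower number from compound 3 to compound 4 (0.15 log units; within the scatter) is the first one-place comparison in this assay, and it concerns butyl in place of 2-phenylethenyl on a carbonyl carbon. Compound 3 and compound 4 do not separate in this assay, even though the group that leaves carries a six-membered aromatic ring and a double bond outside aromatic rings, while butyl has no ring. At this place, then, the exchange of these two groups leaves the tolerated concentration within the scatter, but no measurement shown gives a reason for that result.

As far as these compounds go, only these two groups have been compared on this carbonyl carbon, so it stays open whether an amine, a carboxylic acid or a longer chain there would also stay within the scatter of compound 3. Among the compounds shown here, compound 1 and compound 2 each differ from compound 3 and compound 4 in more than one place, so no steps to them can be read, and the entry for compound 2, which is a limit and not a number, remains unexplained by any one-place change.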